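Replacing benzoyl with oxazolyl on a cytotoxicity read-out

A few compounds are considered here, and "the series" means these few. Any claim that something is new, unique, unknown or untested is made for them only; others in the source may bear on it.

In an ADME assay on PC-3 cells (Homo sapiens) for cytotoxicity, read by WST assay, tested at 100 uM (on this read-out lower numbers stand for less inhibition and higher numbers for more inhibition at the one concentration tested (going by the name of the read-out)), compound 3 `O=C(c1ccccc1)c1cccc(C(=O)N2CCCC(C(=O)Nc3ccc(Cl)cc3)C2)c1` gives 0%, level with compound 2 `CC(C)(C)CC(=O)Nc1cccc(C(=O)N2CCCC(C(=O)Nc3ccc(Cl)cc3)C2)c1` at 0%, and the two together stand lowest of the three measured compounds; no change at the digits printed from compound 2 to compound 3 (within the scatter). Compound 1 `O=C(Nc1ccc(Cl)cc1)C1CCCN(C(=O)c2cccc(-c3nccs3)c2)C1` gives 32%; a number 32 percentage points lower from compound 1 to compound 2 (beyond the scatter). Compound 4 `O=C(Nc1ccc(Cl)cc1)C1CCCN(C(=O)c2cccc(-c3cnco3)c2)C1` differs from compound 3 in one place: 1,3-oxazol-5-yl in place of benzoyl on an aromatic carbon. The measured step that bears on this is the one in which 1,3-thiazol-2-yl, a five-membered aromatic ring with two hetero atoms, was replaced by benzoyl: a number 32 percentage points lower from compound 1 to compound 3 (beyond the scatter). Since compound 4 again carries such a five-membered ring, part of that fall is expected to be undone, a number 18 percentage points higher from compound 3 to compound 4 (beyond the scatter). Compound 4 is therefore estimated at 18%, within 0% to 40%.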

Compound 4, a percentage reported as inhibition, at one concentration (the size of the read-out at that concentration, not a potency): 0%
The estimate for compound 4 lay 18 percentage points above the measured number, and the stated range covers the measured number.
By their numbers in this assay, from the lowest: compounds 2, 3 and 4 (each within the scatter of the next); then compound 1.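

In this assay, carrying a five-membered aromatic ring with 2 hetero atoms at this position is not enough to keep the higher number, with a number 32 percentage points lower from compound 1 to compound 4 (beyond the scatter) on exchanging 1,3-thiazol-2-yl for 1,3-oxazol-5-yl. Compound 4 also sits level with the two compounds that carry open-chain or benzoyl groups here, with no change at the digits printed from compound 3 to compound 4 (within the scatter) and no change at the digits printed from compound 2 to compound 4 (within the scatter) as the two steps, so only compound 1 stands apart. Nothing measured here explains why these two rings differ. Going by these compounds, whether the higher number belongs to 1,3-thiazol-2-yl alone stays open, as does what a pyridine ring or an amine at this place would give.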